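The source may report more compounds than this note shows. Statements on the series, on what has been measured and on what is new or still open speak of the compounds shown alone.

compound 1 `CC(C(=O)NCc1ccc(C(F)(F)F)nc1N(C)C)c1ccc(NS(C)(=O)=O)c(F)c1` — in a functional assay on CHO-K1 cells for antagonist activity at transient receptor potential cation channel subfamily V member 1 (Homo sapiens), read by FLIPR (a lower number here means a stronger inhibitor, a higher number a weaker inhibitor), compound 1 gives 2390 nM
compound 2 `CC(C(=O)NCc1ccc(C(F)(F)F)nc1N1CC=CCC1)c1ccc(NS(C)(=O)=O)c(F)c1` — in this assay compound 2 gives 12.1 nM
compound 3 `CC(C(=O)NCc1ccc(C(F)(F)F)nc1N1CCC(Cc2ccc(F)c(F)c2)CC1)c1ccc(NS(C)(=O)=O)c(F)c1` — in this assay compound 3 gives 30 nM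

Compound 3 holds the second-highest number of the three: compound 2 sits somewhat below it, compound 1 far above it. Compound 4 `CC(C(=O)NCc1ccc(C(F)(F)F)nc1N1CCC(C(F)(F)F)CC1)c1ccc(NS(C)(=O)=O)c(F)c1` differs from compound 3 by trifluoromethyl in place of 3,4-difluorobenzyl on a saturated ring carbon. Within the data shown here, the only single-place step on record, a 200-fold lower number from compound 1 to compound 2 (2.30 log units; beyond the scatter), concerns the group on the aromatic carbon, not the substituent on the saturated ring carbon, so it does not bear directly on this change. Compounds 2 and 3 differ in more than one place; their two numbers lie fairly close together. Among the measured compounds shown here, with no measured step informing the exchange at the saturated ring carbon, only a step near the scatter is expected, a 1.2-fold lower number from compound 3 to compound 4 (0.08 log units; within the scatter). Compound 4 is therefore estimated at 25 nM, with a range of 8 nM to 80 nM.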

Compound 4, half-maximal inhibitory concentration: 31 nM
The estimate for compound 4 lay 1.2-fold (0.09 log units) below the measured number, and the stated range covers the measured number.
By their numbers in this assay, from the lowest: compound 2; then compounds 3 and 4 (each within the scatter of the next); then compound 1.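

In this assay, 3,4-difluorobenzyl and trifluoromethyl on the saturated ring carbon read alike (a 1.0-fold higher number from compound 3 to compound 4 (0.01 log units; within the scatter)), so in this pair the benzyl ring is not required to hold this level of inhibition. On the aromatic carbon, 4-(trifluoromethyl)piperidin-1-yl in place of dimethylamino gives a large gain (a 77-fold lower number from compound 1 to compound 4 (1.89 log units; beyond the scatter)), while a modest loss remains against the unsubstituted unsaturated ring (a 2.6-fold higher number from compound 2 to compound 4 (0.41 log units; beyond the scatter)). No measurement at hand explains why the two substituents read alike. Open, on these data alone, is whether a primary amine, a carboxylic acid or a hydroxyl on that saturated ring carbon would hold the same number.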